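This account rests on a few compounds, and the source may have more. Where it says the series, first, only, none or still open, it means among the compounds named here.

Measured in a toxicity assay on Huh-7 cells (Homo sapiens) for cytotoxicity, with a stated time of 3 days; on this read-out higher numbers stand for lower toxicity in this test and lower numbers for higher toxicity in this test:
Compound 1 `C[C@@]1(O)[C@H](O)[C@@H](CO)O[C@H]1n1cc(-c2cccc3ccccc23)c2c(N)ncnc21`: > 44000 nM, which is a limit of the assay and not a number.
Compound 2 `C[C@@]1(O)[C@H](O)[C@@H](CO)O[C@H]1n1cc(-c2ccc3ccccc3c2)c2c(N)ncnc21`: 20100 nM
Compound 3 `C[C@@]1(O)[C@H](O)[C@@H](CO)O[C@H]1n1cc(-c2ccco2)c2c(N)ncnc21`: 49600 nM

Compound 3 stands at 49600 nM, the higher of the two actual numbers. The nearest number is separated by a 2.5-fold higher number from compound 2 to compound 3 (0.39 log units; beyond the scatter). The next structure, compound 4 `C[C@@]1(O)[C@H](O)[C@@H](CO)O[C@H]1n1cc(-c2ccoc2)c2c(N)ncnc21`, carries furan-3-yl in place of furan-2-yl on an aromatic carbon.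

Within the data shown here, no furan isomer pair has been measured. Among the measured compounds shown here, the closest precedent is the change of attachment in the naphthalene pair, an at least 2.1-fold lower number from compound 1 to compound 2 (0.34 log units; beyond the scatter), which gave a lower number, though its size is only bounded. The exchange of naphthalen-1-yl for furan-2-yl, a step that the limit leaves unreadable from compound 1 to compound 3, adds nothing on size. A small step towards a lower number is therefore expected in this assay, close to the scatter. The expected change is a 1.2-fold lower number from compound 3 to compound 4 (0.09 log units; within the scatter). Compound 4 is estimated at 40000 nM, with an expected range of 20000 nM to 80000 nM.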

Compound 4, half-maximal cytotoxic concentration: > 44000 nM
Compound 4: a limit, no number (the forecaster's own chance of this, stated with the estimate: 30%); middle value at least 1.1-fold (0.04 log units) from the limit.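

In this assay compound 4 gives > 44000 nM, which is a limit of the assay and not a number. Even so, the change of furan-3-yl for naphthalen-2-yl can be read as an at least 2.1-fold higher number from compound 2 to compound 4 (0.34 log units; beyond the scatter), so on this aromatic carbon a higher number than that of the naphthalen-2-yl group is not confined to furan-2-yl. The steps from compound 3 and from compound 1 to compound 4 cannot be read, because the values of compound 1 and compound 4 are limits: the limit of > 44000 nM in this assay, at which 2 of the 4 values shown sit.

Going by these compounds, it remains open whether furan-3-yl and furan-2-yl differ at all in this test. On these data alone, it is also open how a phenyl group or an aminomethyl group would read on this carbon.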